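Removing the aryl methyl: compound 2 to compound 4

This account rests on a few compounds, and the source may have more. Where it says the series, first, only, none or still open, it means among the compounds named here.

The series is read in a functional assay on HL-60 cells (Homo sapiens) for inhibition, read by MTT assay, with a stated time of 72 h; a higher number here means a weaker inhibitor, a lower number a stronger inhibitor. Compound 1 `COc1cc(OC)cc(N2CCN(C(=O)c3oc(C)nc3-c3cccc(F)c3)CC2)c1` gives 28.2 nM in this assay. Compound 3 `O=C(c1oc(C(F)(F)F)nc1-c1ccc(F)cc1)N1CCN(c2cccc(Cl)c2)CC1` is recorded in this assay as "not active" (no number reported), with no number attached. Compound 2 `Cc1ccc(N2CCN(C(=O)c3oc(C)nc3-c3ccccc3)CC2)cc1` reaches only a limit of this assay, giving > 1000 nM, which is a limit and not a number. Among the three entries shown, compound 2 therefore sits at the weak end of this assay, consistent with the limit of > 1000 nM in this assay, at which 1 of the 3 values shown sits, and far from the number given for compound 1.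

Compound 4 `Cc1nc(-c2ccccc2)c(C(=O)N2CCN(c3ccccc3)CC2)o1` is the next compound to be measured. It differs from compound 2 in one place: hydrogen in place of methyl on an aromatic carbon. Cut one bond further out, the change reads 4-methylphenyl to phenyl.

Among the compounds with values here, no step between two measured compounds is available to calibrate a change of this kind, so the expectation rests on the single value of compound 2 alone. The expected step is a step that the limit leaves unreadable from compound 2 to compound 4, that is, nothing beyond the scatter in either direction. Compound 4 is therefore estimated at 2000 nM in this assay, with a range from 500 nM to 8000 nM, and most likely again only a limit would be reported.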

Compound 4, half-maximal inhibitory concentration: 39.1 nM
Beside the measured number, compound 4's estimate is 51-fold (1.71 log units) above it; measured number below the stated range.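

In this assay, within the data shown here, the change from 4-methylphenyl to phenyl gives an at least 25-fold lower number from compound 2 to compound 4 (1.40 log units; beyond the scatter), the first step that can be read between two compounds differing in one place. It shows that this position, on an aromatic carbon para to a large group, is not a silent one: the difference of a single methyl, one heavy atom with no hydrogen-bond donor or acceptor, is enough to carry a large step, and the compound with hydrogen there is the stronger inhibitor of the pair. The true size of the step remains unknown, since only its lower bound can be read, and compound 2 stands at a limit and not a number: the limit of > 1000 nM in this assay, at which 1 of the 4 values shown sits.

As far as these compounds go, what the methyl does at this carbon to produce the step stays open, as no measured property of either compound is given, and a single pair cannot show whether the step is particular to methyl or would follow any group placed there. A hydroxyl, an amine or an ethyl chain on the same carbon would test this, and would show whether the step also holds with other substitution on the rest of the core.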